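The source may hold more compounds than are shown below. What is called first, only, known or untested is meant among the compounds shown, and "the series" means these compounds.

Measured so far:
compound 1, `C/C(=N\NC(=O)c1cccc(S(=O)(=O)N2CCOCC2)c1)c1ccccc1O`, with 5400 nM in a functional assay on MCF7 cells (Homo sapiens) for antiproliferative activity, read by MTT assay, with a stated time of 72 h; on this read-out lower numbers stand for stronger inhibition and higher numbers for weaker inhibition
compound 2, `C/C(=N\NC(=O)c1cccc(S(=O)(=O)N2CCOCC2)c1)c1cc(Br)ccc1O`, with 7830 nM in this assay
compound 3, `O=C(N/N=C/c1cc(Br)ccc1O)c1cccc(S(=O)(=O)N2CCOCC2)c1`, with 26600 nM in this assay

Compound 1 and compound 2 share one core, and they differ by bromo in place of hydrogen on an aromatic carbon. That change made a step of a 1.5-fold higher number from compound 1 to compound 2 (0.16 log units; within the scatter), a step that cannot be told apart from repeat measurements of the same compound. Compound 3 is built on a core of its own, and the difference between the two cores is not broken down here. Among the three, compound 3 gives the highest number, beyond the scatter of the other two.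

Compound 4, `O=C(N/N=C/c1cc(Br)cc(Br)c1O)c1cccc(S(=O)(=O)N2CCOCC2)c1`, has not yet been measured. It differs from compound 3 by bromo in place of hydrogen on an aromatic carbon. Going by the values given here, this is the same kind of change as the one from compound 1 to compound 2, though not the same: there the entering bromo sat meta to a large group and para to a hydroxy group, here it sits ortho to a hydroxy group, meta to a bromo group and meta to a large group.

Because the earlier bromo step gave only a 1.5-fold higher number from compound 1 to compound 2 (0.16 log units; within the scatter), the step from compound 3 to compound 4 is expected to be small as well, estimated at a 1.2-fold higher number from compound 3 to compound 4 (0.08 log units; within the scatter). Compound 4 is therefore expected to give about 32000 nM in this assay, most likely between 12000 nM and 80000 nM.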

Compound 4, half-maximal inhibitory concentration: 16000 nM
Compound 4: the middle estimate sits 2.0-fold (0.30 log units) above what was measured; the measured number falls inside the stated range.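

In this assay, the second bromo gave a 1.7-fold lower number from compound 3 to compound 4 (0.22 log units; within the scatter), so this step is no larger than the differences seen between repeat measurements of a single compound. Set side by side, the two bromo steps cannot be told apart: the same change on two cores in this assay, a 1.5-fold higher number (0.16 log units; within the scatter) from compound 1 to compound 2 and a 1.7-fold lower number (0.22 log units; within the scatter) from compound 3 to compound 4, 2.4-fold (0.38 log units) apart, within the scatter of two such steps. Across these two pairs, then, putting bromo in place of hydrogen on an aromatic carbon carried over from one core to the other without a step that stands out from the scatter, although the bromo enters a different place in each pair; this does not show that bromo is without effect in general, since two small steps in one assay cannot rule out a modest effect hidden in the scatter, and they say nothing about other cores or other cell lines.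

The compounds shown leave open whether a different group on the same aromatic carbon, such as chloro, a methoxy group or an amine, would also stay within the scatter or would give a clear step. They also leave open what happens when the hydroxy group itself is replaced, for example by a methoxy group, while the bromo stays in place.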